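Aryl swap on a hydrazone-urea cytotoxic series

A few compounds are considered here, and "the series" means these few. Any claim that something is new, unique, unknown or untested is made for them only; others in the source may bear on it.

Measured compounds:
compound 1 `COc1cc2c(Oc3ccc(NC(=O)N/N=C/c4ccc(C(F)(F)F)cc4)cc3F)ccnc2cc1OCCCN1CCCC1`: 1800 nM
compound 2 `COc1cc2c(Oc3ccc(NC(=O)N/N=C/c4ccc(C(F)(F)F)cc4)cc3F)ccnc2cc1OCCCN1CCCCC1`: 1100 nM

In a functional assay on MDA-MB-231 cells (Homo sapiens) for cytotoxicity, read by MTT assay, with a stated time of 72 h (a higher number here means a weaker inhibitor, a lower number a stronger inhibitor), compound 2 gives 1100 nM, the lowest of the two numbers shown; compound 1 gives 1800 nM, and the step of a 1.6-fold lower number from compound 1 to compound 2 (0.21 log units; within the scatter) lies within the scatter, so the two compounds cannot be ranked against each other. Compound 3 `COc1cc2c(Oc3ccc(NC(=O)N/N=C/c4ccc(Cl)cc4Cl)cc3F)ccnc2cc1OCCCN1CCCCC1` has not been measured. It differs from compound 2 only at the end of the hydrazone: 2,4-dichlorophenyl in place of 4-(trifluoromethyl)phenyl on a carbon with a double bond to nitrogen. Among the measured compounds shown here, the single measured step, a 1.6-fold lower number from compound 1 to compound 2 (0.21 log units; within the scatter), concerns the amine at the far end of the chain and says nothing about the aryl group on the hydrazone carbon; no measured pair bears on that change. The expectation for compound 3 in this assay is therefore a step of no change at the digits printed from compound 2 to compound 3 (within the scatter), that is, no change beyond the scatter, with a wide range to reflect the missing data. Compound 3 is thus estimated at 1100 nM, between 350 nM and 3500 nM.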

Compound 3, half-maximal inhibitory concentration: 750 nM
Estimate against measurement, compound 3: 1.5-fold (0.17 log units) above; measured number inside the range.
By their numbers in this assay, from the lowest: compounds 3, 2 and 1 (each within the scatter of the next, the first and the last beyond it).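

Among the compounds shown here, this is the first reading at the carbon with a double bond to nitrogen: in this assay, with 2,4-dichlorophenyl in place of 4-(trifluoromethyl)phenyl, the result is a 1.5-fold lower number from compound 2 to compound 3 (0.17 log units; within the scatter). The two aryl groups therefore cannot be ranked against each other, and this position accepts either one, with 8 or 10 heavy atoms in the group, without a step beyond the scatter. Nothing shown here offers an explanation for this reading.

From the compounds shown here alone, what a plain phenyl, a 4-methoxyphenyl or a pyridine ring would give on this carbon remains open, and so does whether any group here can produce a step beyond the scatter. Going by these compounds, it is also open whether 2,4-dichlorophenyl would read the same with pyrrolidin-1-yl or morpholin-4-yl in place of piperidin-1-yl on the chain.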